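Aryl ring swap on the shared core: compound 1 to compound 3

The source may hold more compounds than are shown below. What is called first, only, known or untested is meant among the compounds shown, and "the series" means these compounds.

Measured so far:
compound 1 `c1ccc(-c2cn3ccnc3c(-c3ccc4ncn(C5CCCCC5)c4c3)n2)cc1` — 67.7%
compound 2 `COc1ccccc1-c1cn2ccnc2c(-c2ccc3ncn(C4CCCCC4)c3c2)n1` — 22.4%

In a functional assay on MOLT-4 cells (Homo sapiens) for inhibition, read by sulforhodamine B assay, with a stated time of 48 h, tested at 10 uM (on this read-out lower numbers stand for less inhibition and higher numbers for more inhibition at the one concentration tested (going by the name of the read-out)), compound 1 gives 67.7%, the highest of the two numbers; compound 2 gives 22.4%, the step being a number 45.3 percentage points lower from compound 1 to compound 2 (beyond the scatter). Compound 3 `c1csc(-c2cn3ccnc3c(-c3ccc4ncn(C5CCCCC5)c4c3)n2)c1` differs from compound 1 by thiophen-2-yl in place of phenyl on an aromatic carbon. Among the compounds with values here, no measured step bears on this ring swap; the single measured step, methoxy in place of hydrogen on an aromatic carbon, is a different kind of change and only shows that the number in this assay is much lower after that alteration at this position. A moderate drop is therefore expected, estimated as a number 15.7 percentage points lower from compound 1 to compound 3 (beyond the scatter). Compound 3 is expected to give 52%, in the range 28% to 76%.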

Compound 3, a percentage reported as inhibition, at one concentration (the size of the read-out at that concentration, not a potency): 30.8%
Estimate against measurement, compound 3: 21.2 percentage points above; the range from low to high includes it.
By their numbers in this assay, from the lowest: compounds 2 and 3 (each within the scatter of the next); then compound 1.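

In this assay, thiophen-2-yl in place of phenyl gives a number 36.9 percentage points lower from compound 1 to compound 3 (beyond the scatter), so a change of the ring itself at this position, and not only the added methoxy, lowers the number by a large step. Thiophen-2-yl in place of 2-methoxyphenyl gives a number 8.4 percentage points higher from compound 2 to compound 3 (within the scatter), so these two groups cannot be told apart here. Nothing available explains why either change lowers the number. Still open, going by these compounds, is how a phenyl ring carrying an amine or a carboxylic acid would read at this position, and whether a pyridine ring would hold the number of compound 1.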